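This account rests on a few compounds, and the source may have more. Where it says the series, first, only, none or still open, it means among the compounds named here.

The measured compounds in an assay for inhibition of Nicotinamide phosphoribosyltransferase (Mus musculus), read by fluorescence, with a stated time of 1 h, in the presence of a further agent that is not named here; a lower number here means a stronger inhibitor, a higher number a weaker inhibitor:
Compound 1 `O=C(O)c1cccc(-c2ccccc2C(=O)NCCCCCCCn2cc(-c3cccnc3)nn2)c1` gives only a limit of the assay, > 500 nM.
Compound 2 `O=C(NCCCCCCCn1cc(-c2cccnc2)nn1)c1ccccc1-c1c[nH]nn1` gives 42.5 nM.
Compound 3 `CN(C)Cc1cn(-c2ccccc2C(=O)NCCCCCCCn2cc(-c3cccnc3)nn2)nn1` gives 42.4 nM.

Compound 3 holds the lowest of the two numbers, but compound 2 gives a value within the scatter of it, so no order between these two is claimed. Compound 1 sits at a limit of the assay (the limit of > 500 nM in this assay, at which 1 of the 3 values shown sits). The step of an at least 11-fold lower number from compound 1 to compound 2 (1.07 log units; beyond the scatter) and the step of an at least 11-fold lower number from compound 1 to compound 3 (1.07 log units; beyond the scatter) are both large, whereas the step of a 1.0-fold lower number from compound 2 to compound 3 (0.00 log units; within the scatter) lies within the scatter.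

Compound 4 `O=C(NCCCCCCCn1cc(-c2cccnc2)nn1)c1ccccc1-n1cc(CN2CCCCC2)nn1` differs from compound 3 by piperidin-1-yl in place of dimethylamino on a saturated chain carbon bound to an aromatic carbon. Going by the values given here, none of the measured steps changes exactly this group. The closest comparison is a 1.0-fold lower number from compound 2 to compound 3 (0.00 log units; within the scatter), in which the entire 4-((dimethylamino)methyl)-1H-1,2,3-triazol-1-yl group entered in place of 1H-1,2,3-triazol-4-yl without a shift beyond the scatter; the much smaller exchange within the same group that leads to compound 4 is therefore not expected to move the number either, and the expected step is a 1.1-fold lower number from compound 3 to compound 4 (0.03 log units; within the scatter). On that basis compound 4 is estimated at 40 nM in this assay, with an expected range from 15 nM to 120 nM.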

Compound 4, half-maximal inhibitory concentration: 17.1 nM
Estimate against measurement, compound 4: 2.3-fold (0.37 log units) above; measured number inside the range.
By their numbers in this assay, from the lowest: compound 4; then compounds 3 and 2 (each within the scatter of the next). At a limit, above all of these: compound 1.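

Replacing dimethylamino with piperidin-1-yl on a saturated chain carbon bound to an aromatic carbon shows that the amine at this place can shift the number in this assay, with a 2.5-fold lower number from compound 3 to compound 4 (0.39 log units; beyond the scatter). The earlier pair had shown no such sensitivity, since 4-((dimethylamino)methyl)-1H-1,2,3-triazol-1-yl and 1H-1,2,3-triazol-4-yl could not be told apart, with a 1.0-fold lower number from compound 2 to compound 3 (0.00 log units; within the scatter), whereas 4-((piperidin-1-yl)methyl)-1H-1,2,3-triazol-1-yl does separate from the latter, with a 2.5-fold lower number from compound 2 to compound 4 (0.40 log units; beyond the scatter). The widest step, an at least 29-fold lower number from compound 1 to compound 4 (1.46 log units; beyond the scatter), gives only a bound and not an exact size, because compound 1 stands at a limit rather than at a number: the limit of > 500 nM in this assay, at which 1 of the 4 values shown sits.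

The step from dimethylamino to piperidin-1-yl changes the count of heavy atoms and adds a six-membered non-aromatic ring at once, so the compounds shown cannot say which of the two goes with the lower number. On these data alone, whether a diethylamino group, with an open chain in place of the ring, or a morpholin-4-yl group, with a further oxygen in the ring, would follow compound 4 or compound 3 in this place remains open.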